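The source may hold more compounds than are shown below. What is called first, only, known or untested is meant among the compounds shown, and "the series" means these compounds.

Measured in an ADME assay on NCI-H226 cells (Homo sapiens) for cytotoxicity, read by MTT assay; on this read-out lower numbers stand for stronger inhibition and higher numbers for weaker inhibition:
- Compound 1 `C/C(COc1cccc2ccccc12)=N\O`: > 50000 nM (a limit, not a number)
- Compound 2 `O/N=C(\COc1cccc2ccccc12)c1ccccc1`: 47100 nM
- Compound 3 `O/N=C(\COc1cccc2ccccc12)c1ccc(F)cc1`: > 50000 nM (a limit, not a number)

Within the data shown here, compound 2 gives the only true number of the three, close to the limit of > 50000 nM in this assay, at which 2 of the 3 values shown sit. Compound 4 `O/N=C(\COc1cccc2ccccc12)c1ccc(Cl)cc1`, not yet measured, differs from compound 2 by chloro in place of hydrogen on an aromatic carbon. Among the measured compounds shown here, the one measured step that bears on this is fluoro in place of hydrogen on an aromatic carbon, which gave an at least 1.0-fold higher number from compound 2 to compound 3 (0.02 log units; that floor lies within the scatter). That single step is only a floor, so it is weak guidance. The expected result is a 1.0-fold lower number from compound 2 to compound 4 (0.02 log units; within the scatter), with no change beyond the scatter. For compound 4 the estimate is 45000 nM, with an expected range of 20000 nM to 70000 nM.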

Compound 4, half-maximal inhibitory concentration: > 50000 nM
Compound 4 ended at the assay's limit; the forecaster's own chance of this, stated with the estimate: 45%; middle value at least 1.1-fold (0.04 log units) away from the limit.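

In this assay the change from phenyl to 4-chlorophenyl gives an at least 1.0-fold higher number from compound 2 to compound 4 (0.02 log units; that floor lies within the scatter) and so, like fluoro before it, chloro at this position brings no readable gain in inhibition. The step from compound 3 to compound 4 cannot be read, as both values are limits. Most of the series now sits at one limit: the limit of > 50000 nM in this assay, at which 3 of the 4 values shown sit.

From the compounds shown here alone, whether any group at this position can lower the number remains open. An amine, a carboxylic acid or a methoxy group on the same ring would be a further test of this.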